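The source may hold more compounds than are shown below. What is called first, only, known or untested is meant among the compounds shown, and "the series" means these compounds.

Working notes on the aryl replacement series at the aromatic carbon carrying the amidine-bearing side chain. In a functional assay for activation of Alpha-1A adrenergic receptor (Homo sapiens), read by calcium flux (a higher number here means that more compound is needed for the effect, a lower number that less compound is needed), compound 1 `Cc1nc(-c2ccccc2NCC2=NCCN2)cs1` gives 4.47 nM, compound 2 `Cc1cc(-c2ccccc2NCC2=NCCN2)on1` gives 38.9 nM, and compound 3 `Cc1nc(-c2ccccc2NCC2=NCCN2)no1` gives 724 nM. Compound 3 therefore stands highest of the three numbers: the step of a 19-fold higher number from compound 2 to compound 3 (1.27 log units; beyond the scatter) is large, and the step of a 160-fold higher number from compound 1 to compound 3 (2.21 log units; beyond the scatter) is larger still, so the oxadiazole ring is the least favourable of the three rings measured in this assay. Compound 4 `c1ccc(-c2ccccc2NCC2=NCCN2)nc1` differs from compound 3 as follows: pyridin-2-yl in place of 5-methyl-1,2,4-oxadiazol-3-yl on an aromatic carbon. For the measured compounds named here, no measured step involves pyridin-2-yl itself, so the expectation rests on the two steps into compound 3, both of which show that moving away from the 5-methyl-1,2,4-oxadiazol-3-yl ring lowers the number in this assay. A step of that kind, in the downward direction and beyond the scatter, is expected here as well, estimated as a 24-fold lower number from compound 3 to compound 4 (1.38 log units; beyond the scatter). For compound 4 the estimated value in this assay is 30 nM, with an expected range from 5 nM to 200 nM.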

Compound 4, half-maximal effective concentration: 6.76 nM
Compound 4: the middle estimate sits 4.4-fold (0.65 log units) above what was measured, within the range that was stated.
By their numbers in this assay, from the lowest: compounds 1 and 4 (each within the scatter of the next); then compound 2; then compound 3.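

In this assay the series now shows that this aromatic carbon accepts a six-membered aromatic ring as well as five-membered ones: pyridin-2-yl in place of 5-methyl-1,2,4-oxadiazol-3-yl recovers a large step (a 110-fold lower number from compound 3 to compound 4 (2.03 log units; beyond the scatter)). Pyridin-2-yl also improves on 3-methyl-1,2-oxazol-5-yl (a 5.8-fold lower number from compound 2 to compound 4 (0.76 log units; beyond the scatter)), so ring size alone does not set the number, since the two five-membered rings fall on either side of it. Against 2-methyl-1,3-thiazol-4-yl there is no separation (a 1.5-fold higher number from compound 1 to compound 4 (0.18 log units; within the scatter)), so these two rings cannot be ordered in this assay, even though only the thiazole carries a methyl group.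

From the compounds shown here alone, whether a plain phenyl ring or a pyridin-3-yl ring would hold the number at this carbon remains open, as does the effect of adding a methyl group to the pyridin-2-yl ring. Nothing at hand explains why these rings differ.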